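This account rests on a few compounds, and the source may have more. Where it says the series, first, only, none or still open, it means among the compounds named here.

Among the compounds with values here, in an ADME assay on MT4 cells (Homo sapiens) for cytotoxicity, read by MTT assay (a lower number here means that less compound is tolerated, a higher number that more compound is tolerated), compound 1 (`Cc1ccc(CC2C(=O)N(O)C(=O)c3ccccc32)cc1`) gives 5500 nM, the lower of the two numbers so far, while compound 2 (`CCCCC1C(=O)N(O)C(=O)c2ccccc21`) gives 25400 nM. Compound 3 (`O=C1c2ccccc2C(Cc2ccc(C(F)(F)F)cc2)C(=O)N1O`) keeps the core of compound 1 and carries trifluoromethyl in place of methyl on an aromatic carbon, para to a large group: trifluoromethyl in place of methyl on an aromatic carbon. Within the data shown here, only one measured step bears on this change, and only indirectly: a 4.6-fold higher number from compound 1 to compound 2 (0.66 log units; beyond the scatter). That modest step replaces the whole 4-methylphenyl with propyl, so it is a much broader change than the one at issue. Among the measured compounds shown here, no measured pair isolates a substituent on the aromatic ring, and no direction can be carried over. In this assay, no shift beyond the scatter is therefore expected. The estimated step is a 1.1-fold lower number from compound 1 to compound 3 (0.04 log units; within the scatter). For compound 3 the expected value is 5000 nM, with an estimated range of 2000 nM to 14000 nM.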

Compound 3, half-maximal cytotoxic concentration: 6000 nM
Beside the measured number, compound 3's estimate is 1.2-fold (0.08 log units) below it, and the stated range covers the measured number.
By their numbers in this assay, from the lowest: compounds 1 and 3 (each within the scatter of the next); then compound 2.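

In this assay, within the data shown here, the step at this position is the first to isolate a substituent on the aromatic ring, and trifluoromethyl in place of methyl, para to a large group, stays within the scatter: a 1.1-fold higher number from compound 1 to compound 3 (0.04 log units; within the scatter). Among these compounds, the earlier step, a 4.6-fold higher number from compound 1 to compound 2 (0.66 log units; beyond the scatter), replaced the whole 4-methylphenyl with propyl, and exchanging only this group on the aromatic carbon does not reproduce a shift beyond the scatter. Nothing measured offers a reason for this flat result.

Whether this aromatic carbon also tolerates an amine, a carboxylic acid or a methoxy group remains open, since methyl and trifluoromethyl are the only two groups shown there. Also open, as far as these compounds go, is whether a longer chain in place of propyl would raise the number further.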